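Removing the hydroxymethyl group from compound 1

A few compounds are considered here, and "the series" means these few. Any claim that something is new, unique, unknown or untested is made for them only; others in the source may bear on it.

Measured so far:
compound 1, `OCc1cc(N2CCCC2)ccc1-c1nc2c(s1)C(O)CCC2`: 44 nM
compound 2, `OC1CNCc2nc(-c3ccc(N4CCCC4)cc3)sc21`: 1070 nM

In a functional assay on cells (Homo sapiens) for cytotoxicity, read by sulforhodamine B assay, with a stated time of 2 days (a higher number here means a weaker inhibitor, a lower number a stronger inhibitor), compound 1 gives 44 nM, the lowest of the two numbers in hand. Compound 2 lies at 1070 nM, a gap beyond the scatter, but the two differ in more than one place, so no single step can be read from that pair.

Compound 3, `OC1CCCc2nc(-c3ccc(N4CCCC4)cc3)sc21`, is the next compound to be measured. It differs from compound 1 in one way: hydrogen in place of hydroxymethyl on an aromatic carbon. Among the compounds with values here, no measured pair shows this change on its own. Compound 2 also lacks the hydroxymethyl group and sits well above compound 1 in this assay, although its saturated ring is different, so that comparison is only a hint. The step from compound 1 to compound 3 is therefore expected to weaken inhibition, by a 3.4-fold higher number from compound 1 to compound 3 (0.53 log units; beyond the scatter). Compound 3 is estimated at 150 nM, with a range from 40 nM to 600 nM.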

Compound 3, half-maximal inhibitory concentration: 2800 nM
The estimate for compound 3 lay 19-fold (1.27 log units) below the measured number, and the stated range ends below it.
By their numbers in this assay, from the lowest: compound 1; then compound 2; then compound 3.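

In this assay, putting hydrogen in place of hydroxymethyl on the aromatic carbon ortho to a large group and meta to a pyrrolidin-1-yl group gives a 64-fold higher number from compound 1 to compound 3 (1.80 log units; beyond the scatter), a large step beyond the scatter. Within the data shown here, this is the first change read at a single place, and it shows that this position is far from indifferent: with the rest of the structure unchanged, the hydroxymethyl group alone separates compound 1 from compound 3. No measurement in hand accounts for the size of this step.

The compounds shown cannot tell whether the hydroxyl of the hydroxymethyl group matters or whether any group on this carbon would serve. A methyl, a methoxymethyl, an aminomethyl or a carboxylic acid at this position would be needed to separate these readings.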